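Swapping a Hydroxycyclohexyl Group for an Open Chain

The source may report more compounds than this note shows. Statements on the series, on what has been measured and on what is new or still open speak of the compounds shown alone.

Compound 1 `CC(C)(O)CNc1nc(NCc2ccc(-c3ccco3)cc2)c2ncn(C3CCCC3)c2n1`: 15300 nM
Compound 2 `NC1CCC(Nc2nc(NCc3ccc(-c4ccco4)nc3)c3ncn(C4CCCC4)c3n2)CC1`: 33 nM
Compound 3 `OC1CCC(Nc2nc(NCc3ccc(-c4ccco4)nc3)c3ncn(C4CCCC4)c3n2)CC1`: 390 nM

All three values come from a functional assay on MCF7 cells (Homo sapiens) for inhibition, with a stated time of 72 h; a higher number here means a weaker inhibitor, a lower number a stronger inhibitor. Compound 3 holds the middle place, with a number above that of compound 2 and below that of compound 1. The next compound to be tested, compound 4 `CC(C)(O)CNc1nc(NCc2ccc(-c3ccco3)nc2)c2ncn(C3CCCC3)c2n1`, keeps the rest of compound 3 but carries 2-hydroxy-2-methylpropyl in place of 4-hydroxycyclohexyl on a nitrogen on an aromatic ring.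

Among the measured compounds shown here, only one measured step touches this group: a 12-fold higher number from compound 2 to compound 3 (1.07 log units; beyond the scatter). For the measured compounds named here, that step is large, but the ring stays in place, so it shows only that a change within this group can move the number. It does not measure the loss of the ring. Compound 1, at 15300 nM, carries the same 2-hydroxy-2-methylpropyl group and has the highest number of the three. However, it also differs from compound 4 elsewhere, so it is only a loose guide and the size of the change remains uncertain. Taken together, these data point to a weaker inhibitor, and the expected change is a 6.4-fold higher number from compound 3 to compound 4 (0.81 log units; beyond the scatter). In this assay the estimate for compound 4 is 2500 nM, with an expected range of 600 nM to 10000 nM.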

Compound 4, half-maximal inhibitory concentration: 1310 nM
For compound 4 the middle estimate is 1.9-fold (0.28 log units) above the measured one, within the range that was stated.
By their numbers in this assay, from the lowest: compound 2; then compound 3; then compound 4; then compound 1.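

Among the compounds shown here, the first step measures what the earlier compounds could not: opening the ring while keeping the hydroxy group gives a 3.4-fold higher number from compound 3 to compound 4 (0.53 log units; beyond the scatter) in this assay, a modest change, so this position tolerates the loss of 4-hydroxycyclohexyl without a collapse in the number. The comparison with the amino compound is much wider, at a 40-fold higher number from compound 2 to compound 4 (1.60 log units; beyond the scatter), and compound 2 keeps the lowest number of the four. The last step isolates a second position, since replacing 4-(furan-2-yl)phenyl with 6-(furan-2-yl)pyridin-3-yl gives a 12-fold lower number from compound 1 to compound 4 (1.07 log units; beyond the scatter), which shows that much of the high number of compound 1 lies in that aryl group rather than in the 2-hydroxy-2-methylpropyl chain.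

The compounds shown leave open whether an open chain carrying an amine in place of the hydroxy group, such as 2-amino-2-methylpropyl, would recover the low number seen with 4-aminocyclohexyl. Nothing available here explains why any of these changes moves the number in this way.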